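The source may hold more compounds than are shown below. What is called first, only, known or untested is meant among the compounds shown, and "the series" means these compounds.

Compound 1 `Fc1ccc(C2=NN(C(=S)Nc3ccccc3)C(c3ccc4c(c3)OCCO4)C2)cc1` gives 22500 nM in a functional assay on WM 266-4 cells (Homo sapiens) for antiproliferative activity, read by MTT assay, with a stated time of 48 h; a lower number here means a stronger inhibitor of growth, a higher number a weaker inhibitor of growth. Within the data shown here, compound 2 `O=[N+]([O-])c1ccc(C2=NN(C(=S)Nc3ccccc3)C(c3ccc4c(c3)OCCO4)C2)cc1` gives 105000 nM in this assay, the higher of the two numbers so far; the gap between them is a 4.7-fold higher number from compound 1 to compound 2 (0.67 log units; beyond the scatter). Compound 3 `S=C(Nc1ccccc1)N1N=C(c2ccc(OCc3ccccc3)cc2)CC1c1ccc2c(c1)OCCO2` awaits this assay and differs from compound 2 by benzyloxy in place of nitro on an aromatic carbon. Among the measured compounds shown here, the one measured step that bears on this change is a 4.7-fold higher number from compound 1 to compound 2 (0.67 log units; beyond the scatter), which introduced the nitro group; removing it again is expected to bring the number back down, so the expected step is a 4.2-fold lower number from compound 2 to compound 3 (0.62 log units; beyond the scatter). Compound 3 is therefore estimated at 25000 nM, within 6000 nM to 100000 nM.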

Compound 3, concentration for 50% growth inhibition: 420 nM
For compound 3 the middle estimate is 60-fold (1.77 log units) above the measured one; measured number below the stated range.
By their numbers in this assay, from the lowest: compound 3; then compound 1; then compound 2.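

At this position, para to a large group, the fluoro and nitro compounds did not show how low the number could go in this assay: benzyloxy gives both the step (a 250-fold lower number from compound 2 to compound 3 (2.40 log units; beyond the scatter)) and the step (a 54-fold lower number from compound 1 to compound 3 (1.73 log units; beyond the scatter)). Both are large and exceed the earlier step (a 4.7-fold higher number from compound 1 to compound 2 (0.67 log units; beyond the scatter)), so the fluoro-to-nitro change spanned only a small part of the range seen here. No measured evidence accounts for the gain.

The compounds shown leave open whether the added aromatic ring or the ether oxygen carries the gain. Phenyl and methoxy at this position would separate the two.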